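From a thiazolyl to a pyrazolyl group on compound 3

The compounds below may be only part of what the source reports. "The series", "measured", "known", "first", "only" and "open" are said of these compounds alone.

In a functional assay on MCF7 cells (Homo sapiens) for antiproliferative activity, read by CellTiter-Glo, with a stated time of 5 days (a lower number here means a stronger inhibitor, a higher number a weaker inhibitor), compound 3 `O=C(O)/C=C/c1ccc(/C(=C(\c2ccccc2)C2CCC2)c2ccc(-c3cncs3)cc2)cc1` gives 9.2 nM and compound 2 `O=C(O)/C=C/c1ccc(/C(=C(\c2ccccc2)C2CCC2)c2ccc3scnc3c2)cc1` gives 16 nM, two numbers within the scatter of each other. Compound 1 `CC/C(=C(/c1ccc(/C=C/C(=O)O)cc1)c1ccc(-c2cn[nH]c2)cc1)c1ccccc1` gives 40 nM, a higher number, beyond the scatter from compound 3. Compound 4 `O=C(O)/C=C/c1ccc(/C(=C(\c2ccccc2)C2CCC2)c2ccc(-c3cn[nH]c3)cc2)cc1` has 1H-pyrazol-4-yl in place of 1,3-thiazol-5-yl on an aromatic carbon. The nearest measured step, a 1.7-fold lower number from compound 2 to compound 3 (0.24 log units; within the scatter), involves other groups. Compound 1 carries the same 1H-pyrazol-4-yl group, but on a different core, so it does not isolate this change. No step beyond the scatter is therefore expected, and the estimated step is a 1.1-fold higher number from compound 3 to compound 4 (0.04 log units; within the scatter). For compound 4 the expected value is 10 nM, with an estimated range of 4 nM to 25 nM.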

Compound 4, half-maximal inhibitory concentration: 11 nM
Compound 4: the middle estimate sits 1.1-fold (0.04 log units) below what was measured; measured number inside the range.
By their numbers in this assay, from the lowest: compounds 3, 4 and 2 (each within the scatter of the next); then compound 1.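

In this assay, 1H-pyrazol-4-yl in place of 1,3-thiazol-5-yl gives a 1.2-fold higher number from compound 3 to compound 4 (0.08 log units; within the scatter), so on this aromatic carbon a ring with a hydrogen-bond donor and a ring without one cannot be told apart, and a 1.5-fold lower number from compound 2 to compound 4 (0.16 log units; within the scatter) also stays within the scatter. With the 1H-pyrazol-4-yl group held constant, cyclobutyl in place of ethyl gives a 3.6-fold lower number from compound 1 to compound 4 (0.56 log units; beyond the scatter), which places a modest change at that other site. No measurement here explains either result. Still open, going by these compounds, is whether a non-aromatic group such as an amine at the same carbon would hold these numbers, and whether a longer chain would match cyclobutyl.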